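Vero cytotoxicity: benzylamino in place of methylamino

The compounds below may be only part of what the source reports. "The series", "measured", "known", "first", "only" and "open" are said of these compounds alone.

Measured so far:
compound 1 `CNC1=C([N+](=O)[O-])C(c2ccc(N3CCN(c4ccnc5cc(Cl)ccc45)CC3)cc2)c2ccccc2O1`: > 200000 nM
compound 2 `CNC1=C([N+](=O)[O-])C(c2ccc(N3CCN(c4ccnc5cc(Cl)ccc45)CC3)cc2)c2cccc(OC)c2O1`: 21800 nM

In an ADME assay on Vero cells (Chlorocebus sabaeus) for cytotoxicity, read by MTT assay, with a stated time of 72 h (a higher number here means that more compound is tolerated, a lower number that less compound is tolerated), compound 1 gives only a limit, > 200000 nM. Compound 2 gives 21800 nM in this assay, so the step reads an at least 9.1-fold lower number from compound 1 to compound 2 (0.96 log units; beyond the scatter). Compound 1 therefore stands at the top of the series as far as the numbers go, but only as a limit, (the limit of > 200000 nM in this assay, at which 1 of the 2 values shown sits); how far beyond it the true value lies is not known.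

Compound 3 `O=[N+]([O-])C1=C(NCc2ccccc2)Oc2ccccc2C1c1ccc(N2CCN(c3ccnc4cc(Cl)ccc34)CC2)cc1` carries phenyl in place of hydrogen on a saturated chain carbon bound to an amine nitrogen. Going by the values given here, no measured step touches this position: the one step recorded changes a substituent on an aromatic carbon of the shared core, and nothing in the data shows how a change on the amine substituent behaves in this assay. The expectation is a small move downward from the limit, an at least 2.0-fold lower number from compound 1 to compound 3 (0.30 log units; that floor lies within the scatter), with a real chance that compound 3 again reports only a limit. Compound 3 is estimated at 100000 nM, with a range from 30000 nM to 200000 nM.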

Compound 3, half-maximal cytotoxic concentration: 66500 nM
The estimate for compound 3 lay 1.5-fold (0.18 log units) above the measured number; the measured number falls inside the stated range.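

In this assay, the amine substituent now has a reading of its own, whereas the earlier step spoke only of an aromatic carbon of the shared core. Benzylamino in place of methylamino gives an at least 3.0-fold lower number from compound 1 to compound 3 (0.47 log units; beyond the scatter), so a change on a saturated chain carbon bound to an amine nitrogen also moves the number beyond the scatter. The true size of this step stays unknown, and the printed figure is only a floor, because compound 1 stands at a limit and not at a number: the limit of > 200000 nM in this assay, at which 1 of the 3 values shown sits.

The compounds shown leave open whether the step belongs to the phenyl ring as such or would also appear with an ethylamino group, a longer saturated chain on the amine or a cyclohexylmethylamino group in its place. They also leave open whether benzylamino and methoxy would act independently on one core, and whether a phenethylamino group, with its ring set one carbon further out, would continue the same direction in this read-out.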